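This account rests on a few compounds, and the source may have more. Where it says the series, first, only, none or still open, it means among the compounds named here.

The study concerns a small set of agonists built on one shared core. Compound 1 `COc1cc2nc(Nc3ccc(S(C)(=O)=O)cc3)nc(OC3CCN(C(=O)OC(C)(C)C)CC3)c2cc1OC` was tested in a functional assay on HEK293 cells for agonist activity at Glucose-dependent insulinotropic receptor (Homo sapiens), read by cAMP accumulation, with a stated time of 60 min; a higher number here means that more compound is needed for the effect, a lower number that less compound is needed. In this assay compound 1 reaches only a limit, > 10000 nM, and not a number. Compound 2 `COc1cc2nc(Nc3ccc(S(C)(=O)=O)cc3)nc(OCC3CCN(C(=O)OC(C)(C)C)CC3)c2cc1OC` carries the same core with a longer link to its saturated ring. In this assay compound 2 likewise reaches only a limit, > 10000 nM. Where compound 1 stands is therefore told by a single line: the limit of > 10000 nM in this assay, at which 2 of the 2 values shown sit. Going by the values given here, no pair of measured compounds differs in just one place, so no measured step is available.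

Compound 3 `COc1cc2nc(Nc3ccc(S(C)(=O)=O)cc3F)nc(OC3CCN(C(=O)OC(C)(C)C)CC3)c2cc1OC` has not yet been measured in this assay. Compared with compound 1 it differs in one place: fluoro in place of hydrogen on an aromatic carbon. Because compound 1 already sits at the limit of > 10000 nM in this assay, at which 2 of the 2 values shown sit, any change is expected to be none beyond the scatter. The expected step that the limit leaves unreadable from compound 1 to compound 3 is thus a flat one. Compound 3 is estimated at 15000 nM, with a range from 5000 nM to 50000 nM, and most likely the assay will again report only a limit.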

Compound 3, half-maximal effective concentration: > 10000 nM
Compound 3 gave a limit, no number; the forecaster's own chance of this, stated with the estimate: 85%; the middle value is on the limit's open side.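

Compound 3 gives only a limit in this assay, as compound 1 does, so no step from compound 1 to compound 3 can be read: the limit of > 10000 nM in this assay, at which 3 of the 3 values shown sit.

The compounds shown leave open whether fluoro in place of hydrogen changes anything in this assay, and what on the shared core would give a measurable number there.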